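Amide aryl swap on a quinoline antiproliferative series

The source may report more compounds than this note shows. Statements on the series, on what has been measured and on what is new or still open speak of the compounds shown alone.

Measured compounds:
- compound 1, `CCN1CCN(c2cc(C)c3cc(NC(=O)c4cccc(Cl)c4)ccc3n2)CC1`: 3820 nM
- compound 2, `Cc1cc(NCCN2CCN(C)CC2)nc2ccc(NC(=O)c3ccc(Cl)c(Cl)c3)cc12`: 1700 nM

Of the compounds shown here, two of the shared core have been measured in a functional assay on MCF7 cells (Homo sapiens) for antiproliferative activity, read by MTT assay, with a stated time of 72 h; on this read-out higher numbers stand for weaker inhibition and lower numbers for stronger inhibition. Compound 1 gives 3820 nM, the highest of the two numbers. Compound 2 differs from compound 1 in several places. Compound 2 gives 1700 nM, a lower number that lies beyond the usual scatter. Among the measured compounds shown here, no single-change step between measured compounds is available.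

Compound 3, `CCc1ccccc1C(=O)Nc1ccc2nc(N3CCN(CC)CC3)cc(C)c2c1`, has not yet been measured. It differs from compound 1 in one place: 2-ethylphenyl in place of 3-chlorophenyl on a carbonyl carbon. For the measured compounds named here, nothing among the measured compounds shows what this change does on its own.

Since the change swaps one six-membered carbon-only ring for another of the same kind, a step of at most modest size is expected, with weaker inhibition as the more likely direction; the expected step from compound 1 to compound 3 is a 1.3-fold higher number from compound 1 to compound 3 (0.12 log units; within the scatter). Compound 3 is therefore estimated at 5000 nM, with a range of 1500 nM to 16000 nM.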

Compound 3, half-maximal inhibitory concentration: 15800 nM
Estimate against measurement, compound 3: 3.2-fold (0.50 log units) below; low and high end bracket the measured number.
By their numbers in this assay, from the lowest: compound 2; then compound 1; then compound 3.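

In this assay the group on the carbonyl carbon is now shown to matter on its own: with the rest of compound 1 kept, 2-ethylphenyl in place of 3-chlorophenyl gives a 4.1-fold higher number from compound 1 to compound 3 (0.62 log units; beyond the scatter) and so weakens inhibition. Among the compounds shown here, this is the first single-change step, and it shows that this position responds even when one six-membered aromatic ring of carbon only replaces another, with no hydrogen-bond donors, hydrogen-bond acceptors or net charge on either group. No measurement shown accounts for the size or direction of this step.

For the compounds shown here, the single step does not separate the loss of the chlorine from the entry of the ethyl group, and a plain phenyl, a methoxy group or an amine on that ring could each give a different answer. As far as these compounds go, compound 2 differs from compound 1 in several places, so it remains open whether its amide aryl group, its chain bearing the methylpiperazine or both set its number.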